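The source may hold more compounds than are shown below. What is called first, only, known or untested is meant among the compounds shown, and "the series" means these compounds.

Measured compounds:

- compound 1, `ClCc1ccc(Cn2cnc3c(Cl)ncnc32)cc1`: in a functional assay on ACHN cells (Homo sapiens) for cytotoxicity, read by sulforhodamine B assay, with a stated time of 48 h (on this read-out lower numbers stand for stronger inhibition of growth and higher numbers for weaker inhibition of growth), compound 1 gives 310 nM
- compound 2, `ClCc1ccccc1Cn1cnc2c(Cl)nc(Cl)nc21`: in this assay compound 2 gives 470 nM

Among the compounds with values here, compound 2 carries the highest number of the two measured so far. Its nearest neighbour on this read-out is compound 1, whose number is lower by a margin that stays within the usual scatter of repeated measurements, so the two cannot be ordered against each other.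

The next compound in the series is compound 3, `ClCc1ccccc1Cn1cnc2c(Cl)ncnc21`. It is derived from compound 2 by the change (hydrogen in place of chloro on an aromatic carbon). The site is an aromatic carbon of a six-membered aromatic ring with two nitrogen atoms, between two ring nitrogen atoms, part of the fused system of two rings of the shared core.

Within the data shown here, no step between measured compounds describes this particular change, so there is no measured precedent for its size. The expectation is a small step, if any, and not one beyond the scatter in either direction; the expected step from compound 2 to compound 3 is a 1.1-fold lower number from compound 2 to compound 3 (0.05 log units; within the scatter). For compound 3 the number expected in this assay is 420 nM, with a range from 150 nM to 1200 nM.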

Compound 3, concentration for 50% growth inhibition: 2700 nM
For compound 3 the middle estimate is 6.4-fold (0.81 log units) below the measured one, and the stated range ends below it.
By their numbers in this assay, from the lowest: compounds 1 and 2 (each within the scatter of the next); then compound 3.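

In this assay, within the data shown here, the site between two ring nitrogen atoms proves not to be neutral: hydrogen in place of chloro there gives a 5.7-fold higher number from compound 2 to compound 3 (0.76 log units; beyond the scatter) and is the first step beyond the scatter. The effect of the site does not extend to every compound with hydrogen there, since compound 1 also carries hydrogen at this carbon and differs from compound 3 only in where the chloromethyl group stands, yet compound 1 gives 310 nM in this assay against the higher printed number of compound 3. No measurement at hand bears on why the number rises with this change.

Only chloro and hydrogen are shown at this site, so it remains open whether an amine, a methoxy group or a fluoro group there would stay near compound 2 or near compound 3. Also open, on these data alone, is whether chloro at this site would matter to the same extent with the chloromethyl group placed as in compound 1, since that compound has no partner carrying chloro at the site.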